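Swapping an ethoxy for a methanesulfonamide on the biphenyl end

This account rests on a few compounds, and the source may have more. Where it says the series, first, only, none or still open, it means among the compounds named here.

Measured so far:
compound 1, `CCC(CC)C(N)CCN(C(=O)[C@@H]1C[C@H]1c1ccccc1)c1ccc(-c2ccccc2)cc1`, 2 nM
compound 2, `CC[C@H](C)[C@H](N)CN(C(=O)[C@@H]1C[C@H]1c1cc(F)cc(F)c1)c1ccc(-c2ccccc2)cc1`, 960 nM
compound 3, `CCOc1ccc(-c2ccc(N(C[C@@H](N)[C@@H](C)CC)C(=O)[C@@H]3C[C@H]3c3ccccc3)cc2)cc1`, 90 nM

All three compounds were tested in a functional assay for agonist activity at G protein-coupled receptor 88 (Homo sapiens), read by HTRF and cAMP accumulation; on this read-out higher numbers stand for an effect only at larger amounts of compound and lower numbers for an effect already at smaller amounts. Compound 1 gives the lowest number, 2 nM, and compound 2 the highest, 960 nM. Compound 3, with 90 nM, stands between them, nearer to compound 2 than to compound 1; both of its gaps to the other two lie beyond the usual scatter, so the ordering among the three is real.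

Compound 4, `CC[C@H](C)[C@H](N)CN(C(=O)[C@@H]1C[C@H]1c1ccccc1)c1ccc(-c2ccc(NS(C)(=O)=O)cc2)cc1`, has not been measured yet. It differs from compound 3 only at the far ring of the biphenyl: methanesulfonamido in place of ethoxy on an aromatic carbon. The chain bearing the amine and the phenyl-cyclopropane amide are kept as in compound 3. Among the measured compounds shown here, no pair of measured compounds shows what this particular swap does, so the direction can only be guessed. The expectation is a modest move toward lower numbers, of size a 2.3-fold lower number from compound 3 to compound 4 (0.35 log units; beyond the scatter), which may well stay within the scatter. Compound 4 is therefore estimated at 40 nM, with a range from 8 nM to 200 nM.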

Compound 4, half-maximal effective concentration: 1200 nM
Compound 4: middle estimate off by 30-fold (1.48 log units), on the low side; the measured number lies above the stated range.
By their numbers in this assay, from the lowest: compound 1; then compound 3; then compounds 2 and 4 (each within the scatter of the next).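

Among the compounds shown here, this is the first direct reading of what the far aromatic ring tolerates: with the amine-bearing chain and the phenyl-cyclopropane amide held constant, putting methanesulfonamido in place of ethoxy on an aromatic carbon, para to a large group, gives a 13-fold higher number from compound 3 to compound 4 (1.12 log units; beyond the scatter) in this assay. The number at this position therefore depends strongly on the group placed there, and this swap moves it toward larger amounts of compound. The swap also brings in a hydrogen-bond donor that ethoxy lacks, but nothing available here explains the rise.

From the compounds shown here alone, whether a methoxy, a hydroxyl or a carboxylic acid at this same place would stay close to compound 3 or to compound 4 remains open. Also open, going by these compounds, is whether the same swap would give a step of similar size on the amine-bearing chain of compound 1.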